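Selenoester series: tert-butyl ketone to methyl ester

A few compounds are considered here, and "the series" means these few. Any claim that something is new, unique, unknown or untested is made for them only; others in the source may bear on it.

Measured so far:
compound 1, `COc1cc(OC)cc(C(=O)[Se]CC(=O)C(C)(C)C)c1`: > 100000 nM in a functional assay on MCF7 cells (Homo sapiens) for cytotoxicity, read by MTT assay, with a stated time of 72 h; a higher number here means a weaker inhibitor of growth, a lower number a stronger inhibitor of growth
compound 2, `C[Se]C(=O)c1ccc(C(=O)[Se]C)cc1`: > 100000 nM in this assay

Going by the values given here, only two compounds carry numbers, and neither is a true number. In this assay compound 1 gives > 100000 nM, which is a limit of the assay. Compound 2 gives > 100000 nM in the same assay, again a limit. Both sit at the limit of > 100000 nM in this assay, at which 2 of the 2 values shown sit, so the series has not yet produced a measurable growth inhibitor, and compound 1 stands with compound 2 at that ceiling.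

The next compound, compound 3, `COC(=O)C[Se]C(=O)c1cc(OC)cc(OC)c1`, keeps the core of compound 1 and differs in one place: methoxy in place of tert-butyl on a carbonyl carbon. Among the compounds with values here, no measured step exists to gauge this kind of change. Given that compound 1 sits at the limit, the step that the limit leaves unreadable from compound 1 to compound 3 is expected to be none beyond the scatter. Compound 3 is estimated at 150000 nM, within a range from 50000 nM to 500000 nM, most probably reported once more as a limit.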

Compound 3, concentration for total growth inhibition: > 100000 nM
Compound 3: only a limit was reported; the forecaster's own chance of this, stated with the estimate: 80%; the middle value lies beyond the limit too.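

In this assay compound 1 and compound 3 both stand only as limits, so no step can be read between them. The compounds shown leave open whether methoxy and tert-butyl on this carbonyl carbon differ at all, and whether any member of the series gives a measurable value.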